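Methoxy to isopropoxy: compound 3 to compound 4

The compounds below may be only part of what the source reports. "The series", "measured", "known", "first", "only" and "open" are said of these compounds alone.

Among the compounds with values here, in a functional assay on MCF7 cells (Homo sapiens) for antiproliferative activity, read by MTT assay, with a stated time of 48 h (on this read-out lower numbers stand for stronger inhibition and higher numbers for weaker inhibition), compound 3 (`COc1cc(-c2nnc3c(OC)cc(-c4ccc5c(ccn5C)c4)cn23)cc(OC)c1OC`) gives 49 nM, the lowest of the three numbers so far. Compound 2 (`CCOc1cc(-c2ccc3c(ccn3C)c2)cn2c(-c3cc(OC)c(OC)c(OC)c3)nnc12`) gives 140 nM, and compound 1 (`COc1cc(-c2nnc3c(OC(C)C)cc(-c4ccc5[nH]ccc5c4)cn23)cc(OC)c1OC`) gives 1020 nM.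

Compound 4 (`COc1cc(-c2nnc3c(OC(C)C)cc(-c4ccc5c(ccn5C)c4)cn23)cc(OC)c1OC`) changes compound 3 from methoxy to isopropoxy, with isopropyl in place of methyl on an oxygen on an aromatic ring.

Within the data shown here, one measured step bears directly on this change: a 2.9-fold lower number from compound 2 to compound 3 (0.46 log units; beyond the scatter). It is modest but beyond the scatter, and read in reverse it links a larger group on that oxygen with a higher number. Compound 1 also carries isopropoxy, but it differs from compound 4 elsewhere, so compound 1 at 1020 nM offers only loose support. Among the measured compounds shown here, no measured step isolates isopropoxy itself.

A step larger than the measured one is therefore expected in this assay, towards a higher number. The expected step is a 6.1-fold higher number from compound 3 to compound 4 (0.79 log units; beyond the scatter). Compound 4 is estimated at 300 nM, with an expected range of 120 nM to 750 nM.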

Compound 4, half-maximal inhibitory concentration: 204 nM
The estimate for compound 4 lay 1.5-fold (0.17 log units) above the measured number; the measured number falls inside the stated range.
By their numbers in this assay, from the lowest: compound 3; then compounds 2 and 4 (each within the scatter of the next); then compound 1.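

In this assay, the change from methoxy to isopropoxy now stands alone, with nothing else altered on the core (a 4.2-fold higher number from compound 3 to compound 4 (0.62 log units; beyond the scatter)). One methyl in place of hydrogen on the saturated chain carbon of that oxygen substituent does not separate the two larger groups (a 1.5-fold higher number from compound 2 to compound 4 (0.16 log units; within the scatter)), so on this oxygen only compound 3, the methoxy member, stands apart from both. With isopropoxy held constant, a second place also moves the number, methyl in place of hydrogen on an aromatic nitrogen (a 5.0-fold lower number from compound 1 to compound 4 (0.70 log units; beyond the scatter)), so the number of compound 1 cannot be read as an isopropoxy effect alone. No measurement shown gives a reason for any of these steps.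

Still open, on these data alone, is how a free hydroxyl, a longer chain or an amine-bearing chain on that oxygen would read. Also open, as far as these compounds go, is whether an ethyl group on the aromatic nitrogen would keep the step seen with methyl.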